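The source may hold more compounds than are shown below. What is called first, only, known or untested is meant among the compounds shown, and "the series" means these compounds.

Compounds measured so far:
- compound 1, `C/C=C/C(=O)N(Cc1cccc(O)c1)c1cc(OC)c(OC)c(OC)c1`, gives 14100 nM
- compound 2, `C#CC(=O)N(Cc1ccc(OC)c(O)c1)c1cc(OC)c(OC)c(OC)c1`, gives 170 nM
- compound 3, `C/C=C/C(=O)N(Cc1ccc(OC)c([N+](=O)[O-])c1)c1cc(OC)c(OC)c(OC)c1`, gives 590 nM

All three were tested in a functional assay on MGC-803 cells (Homo sapiens) for inhibition, read by MTT assay, with a stated time of 48 h; a lower number here means a stronger inhibitor, a higher number a weaker inhibitor. Among them, compound 2 has the lowest number, and its gap to each of the other two lies beyond the usual scatter: compound 3 stands above it, and compound 1 stands well above it. All three share the same core, with a trimethoxyphenyl on an amide-type nitrogen and a substituted benzyl group; they differ in the benzyl substituents and in the group on the carbonyl carbon.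

The unmeasured compound 4, `CC/C=C/C(=O)N(Cc1ccc(OC)c(O)c1)c1cc(OC)c(OC)c(OC)c1`, keeps the benzyl group of compound 2 and changes only the acyl side: but-1-en-1-yl in place of ethynyl on a carbonyl carbon. Among the measured compounds shown here, no pair of measured compounds differs in exactly this way, so the size of this step cannot be read from the data; compounds 1 and 3 carry an alkenyl group on the carbonyl and both sit above compound 2, but they also differ from it on the benzyl ring. A weakening step of moderate size is expected, that is, the number is expected to rise from compound 2 to compound 4 by a 4.7-fold higher number from compound 2 to compound 4 (0.67 log units; beyond the scatter). Compound 4 is therefore estimated at 800 nM, within a range of 200 nM to 4000 nM.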

Compound 4, half-maximal inhibitory concentration: 58 nM
The estimate for compound 4 lay 14-fold (1.14 log units) above the measured number; the whole stated range lies above it.
By their numbers in this assay, from the lowest: compound 4; then compound 2; then compound 3; then compound 1.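

Among the compounds shown here, compound 2 and compound 4 form the first pair that differs in one place, so the effect of the group on the carbonyl carbon can now be read directly. In this assay, but-1-en-1-yl in place of ethynyl gives a 2.9-fold lower number from compound 2 to compound 4 (0.47 log units; beyond the scatter), a modest change that lies beyond the usual scatter. Ethynyl is therefore not required for a strong result in this series, and this position accepts a chain with a double bond and more carbons, though nothing shown here explains the gain.

Still open, as far as these compounds go, is how a saturated butyl chain, a longer alkenyl chain or a chain carrying an amine on the same carbonyl carbon would compare with but-1-en-1-yl. Also open, from the compounds shown here alone, is whether this step keeps its direction and size with a different substituted benzyl group.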